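Carboxy to carbamoyl: the step to compound 4

A few compounds are considered here, and "the series" means these few. Any claim that something is new, unique, unknown or untested is made for them only; others in the source may bear on it.

- compound 1 `O=C(O)c1ccc(CCOc2c(F)ccc3nc(C(=O)NCc4ccccc4)[nH]c(=O)c23)cc1` gives 6.3 ug/mL
- compound 2 `CCc1cccc(CNC(=O)c2nc3cccc(COCc4ccc(C(=O)O)cc4)c3c(=O)[nH]2)c1` gives < 1.6 ug/mL
- compound 3 `CCc1cncc(CNC(=O)c2nc3cccc(COCc4ccc(C(=O)O)cc4)c3c(=O)[nH]2)c1` gives 1.6 ug/mL

These readings come from a physicochemical assay for solubility, read by nephelometry, in phosphate buffer, measured as kinetic solubility, at pH 6.5 (a lower number here means a less soluble compound, a higher number a more soluble compound), and are the only ones available. Compound 2 reads < 1.6 ug/mL as a limit of the assay and not a number. Its place is therefore only a bound (the limit of < 1.6 ug/mL in this assay, at which 1 of the 3 values shown sits).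

Compound 4 `CCc1cccc(CNC(=O)c2nc3cccc(COCc4ccc(C(N)=O)cc4)c3c(=O)[nH]2)c1` has amino in place of hydroxy on a carbonyl carbon, which turns 4-carboxybenzyl into 4-carbamoylbenzyl. Going by the values given here, the one measured step (a number no lower from compound 2 to compound 3 (the limit leaves the size open)) swaps a different group, and its size cannot be read, so it gives no measure for this change. Among the compounds with values here, compound 1 differs from the others in more than one place and offers no step either. Compound 3 gives 1.6 ug/mL, and from that reading no step beyond the usual scatter is expected in this assay for this swap. The estimated change is a number no lower from compound 2 to compound 4 (the limit leaves the size open) and remains an expectation only. Compound 4 is estimated at 1.6 ug/mL with an expected range of 0.8 ug/mL to 4 ug/mL before any measurement.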

Compound 4, solubility: < 3.1 ug/mL
Compound 4: only a limit was reported; the forecaster's own chance of this, stated with the estimate: 60%; the middle value lies beyond the limit too.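

Going by these compounds alone, compound 2 and compound 4 both stand as limits of the assay and not as numbers, and no step between them can be read. The compounds shown leave open the size and direction of the change from 4-carboxybenzyl to 4-carbamoylbenzyl in this assay.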